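A few compounds are considered here, and "the series" means these few. Any claim that something is new, unique, unknown or untested is made for them only; others in the source may bear on it.

Working notes on the series. Compound 1 `COc1ccc(CNc2nc3cc(N)cc(N)c3nc2-c2ccccc2)cc1OC` and compound 2 `Nc1cc(N)c2nc(-c3ccccc3)c(NCc3ccc(F)cc3)nc2c1` share the same core and differ only in the aryl group on the saturated chain carbon bound to the ring nitrogen. In a functional assay on PC-3 cells (Homo sapiens) for inhibition, read by sulforhodamine B assay, with a stated time of 48 h (a higher number here means a weaker inhibitor of growth, a lower number a stronger inhibitor of growth), compound 1 gives 8320 nM, and compound 2 gives 3470 nM; the step of a 2.4-fold lower number from compound 1 to compound 2 (0.38 log units; beyond the scatter) is modest but beyond the scatter, so compound 2 has the lower of the two numbers in this assay.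

Compound 3 `Nc1cc(N)c2nc(-c3ccccc3)c(Sc3ccc(Cl)c(Cl)c3)nc2c1` is not yet measured. It differs from compound 2 by (3,4-dichlorophenyl)sulfanyl in place of (4-fluorobenzyl)amino on an aromatic carbon. Within the data shown here, the only measured step, a 2.4-fold lower number from compound 1 to compound 2 (0.38 log units; beyond the scatter), concerns a swap of the aryl group while the amino linker was kept, so it bears only loosely on a change that exchanges the linker itself; no measured pair covers a sulfanyl link in this assay. A step within or near the scatter in either direction is therefore expected, with wide uncertainty. For compound 3 the value in this assay is estimated at 3000 nM, range 700 nM to 13000 nM, which means an expected step of a 1.2-fold lower number from compound 2 to compound 3 (0.06 log units; within the scatter).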

Compound 3, concentration for 50% growth inhibition: 3470 nM
Compound 3: middle estimate off by 1.2-fold (0.06 log units), on the low side; the measured number falls inside the stated range.
By their numbers in this assay, from the lowest: compounds 2 and 3 (each within the scatter of the next); then compound 1.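

In this assay, replacing the (4-fluorobenzyl)amino group with (3,4-dichlorophenyl)sulfanyl on the aromatic carbon gives no change at the digits printed from compound 2 to compound 3 (within the scatter). Unlike the earlier step, which kept the amino link and changed only the aryl group, this one exchanges the link and the aryl substitution together, and the entering group has no hydrogen-bond donor; at this position, then, the amino link and its hydrogen are not needed for a number of this size. No supporting data bear on why the two numbers coincide.

Because both parts changed at once, the compounds shown leave open whether the link and the aryl substitution each have no effect or have effects that offset each other. A 4-fluorophenylsulfanyl group would separate the two, while a sulfonyl or ether oxygen link would test how far the position accepts other links.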